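A few compounds are considered here, and "the series" means these few. Any claim that something is new, unique, unknown or untested is made for them only; others in the source may bear on it.

In an ADME assay on GES1 cells (Homo sapiens) for inhibition, read by MTT assay, with a stated time of 72 h (a lower number here means a stronger inhibitor, a higher number a weaker inhibitor), compound 2 `Cc1cc(Nc2cc(-c3cccs3)[nH]n2)n2nc(SCc3ccc(Br)cc3)nc2n1` gives 38700 nM. That value lies within the scatter of compound 1 `Cc1cc(Nc2cc(-c3ccccc3)[nH]n2)n2nc(SCCc3ccccc3)nc2n1` at 37400 nM and of compound 3 `Cc1cc(Nc2cc(-c3ccccc3)[nH]n2)n2nc(SCc3ccc(Cl)cc3)nc2n1` at 31800 nM. Compound 4 `Cc1cc(Nc2cc(-c3ccc(Cl)cc3)[nH]n2)n2nc(SCc3ccc(Br)cc3)nc2n1`, still unmeasured, carries 4-chlorophenyl in place of thiophen-2-yl on an aromatic carbon. Among the compounds with values here, no measured pair shows this change on its own. Within the data shown here, the only measured single-place step, a 1.2-fold lower number from compound 1 to compound 3 (0.07 log units; within the scatter), concerns a different place, the group on the sulfur, and it stays within the scatter. With so little to go on, and all three values close together, no change beyond the scatter is expected. The expected step is a 1.2-fold lower number from compound 2 to compound 4 (0.08 log units; within the scatter). For compound 4 the estimated value is 32000 nM, with an expected range from 16000 nM to 60000 nM.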

Compound 4, half-maximal inhibitory concentration: 28200 nM
For compound 4 the middle estimate is 1.1-fold (0.05 log units) above the measured one; measured number inside the range.
By their numbers in this assay, from the lowest: compounds 4, 3, 1 and 2 (each within the scatter of the next).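

Within the data shown here, this is the first step that can be read at this aromatic carbon of the five-membered aromatic ring with 2 nitrogen. In this assay, 4-chlorophenyl in place of thiophen-2-yl gives a 1.4-fold lower number from compound 2 to compound 4 (0.14 log units; within the scatter), so the two compounds cannot be told apart, even though the two groups differ in ring size and atoms. No supporting measurement bears on this result. On these data alone, it remains open whether an amine or a carboxylic acid on this aromatic carbon would shift the number beyond the scatter. The same question applies to a longer chain on the sulfur.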